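The compounds below may be only part of what the source reports. "The series", "measured", "known", "first", "only" and "open" are said of these compounds alone.

Compound 3 `COc1ccc(C2=NN(C3=NC(=O)/C(=C4\C(=O)Nc5ccccc54)S3)C(c3ccc(Cl)cc3)C2)cc1` is the weakest of the three compounds measured in a functional assay on cells (Cancer cell lines, Homo sapiens) for cytotoxicity, read by sulforhodamine B assay, with a stated time of 48 h; a lower number here means a stronger inhibitor of growth, a higher number a weaker inhibitor of growth: compound 3 gives 100000 nM. Among the measured compounds shown here, compound 2 `O=C1N=C(N2N=C(c3ccccc3)CC2c2ccc(Cl)cc2)S/C1=C1/C(=O)Nc2ccccc21` gives 6290 nM in this assay, and the single change from it, a 16-fold higher number from compound 2 to compound 3 (1.20 log units; beyond the scatter), shows how much a methoxy in place of hydrogen on an aromatic carbon shifted the number. For the measured compounds named here, compound 1 `COc1ccc(C2=NN(C3=NC(=O)/C(=C4\C(=O)Nc5ccc(Br)cc54)S3)C(c3ccc(OC)cc3)C2)cc1` gives 430 nM in this assay; it carries the bromo as well as two methoxy groups, and differs from compound 3 in two places, so no single step connects it to compound 3.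

Compound 4 `COc1ccc(C2=NN(C3=NC(=O)/C(=C4\C(=O)Nc5ccc(Br)cc54)S3)C(c3ccc(Cl)cc3)C2)cc1` arises from compound 3 by bromo in place of hydrogen on an aromatic carbon. Going by the values given here, none of the measured steps is of this kind: the only single step recorded concerns a methoxy, not a bromo, so it does not bear directly on the change to compound 4. Compound 1 and compound 4 share the bromo and differ only in a chloro against a methoxy on the other aryl ring, and the value of compound 1 suggests that the bromo-bearing series can sit much lower than compound 3 does. On that basis compound 4 is expected to give 8000 nM in this assay, within 800 nM to 80000 nM, which would mean a step of a 13-fold lower number from compound 3 to compound 4 (1.10 log units; beyond the scatter); the estimate is uncertain because compound 3 sits at 100000 nM and only compound 1 hints at the effect of the bromo.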

Compound 4, concentration for total growth inhibition: 340 nM
Compound 4: the middle estimate sits 24-fold (1.37 log units) above what was measured; the whole stated range lies above it.
By their numbers in this assay, from the lowest: compounds 4 and 1 (each within the scatter of the next); then compound 2; then compound 3.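

In this assay, the bromo in place of hydrogen on an aromatic carbon of the six-membered ring, part of a fused or bridged system of two rings, gives a 290-fold lower number from compound 3 to compound 4 (2.47 log units; beyond the scatter), so this single change on its own produces a large drop in the number. The earlier compounds shown here showed the bromo only in compound 1, alongside two methoxy groups, and so could not separate its contribution from theirs. The exchange on the other aryl ring, with a 1.3-fold lower number from compound 1 to compound 4 (0.10 log units; within the scatter), lies within the scatter, so with the bromo in place, chloro and methoxy at that site cannot be told apart here, and nothing available explains why the bromo has so large an effect.

On these data alone, only hydrogen and bromo appear at this position, so it remains open whether fluoro, chloro, methyl, an amine or a carboxylic acid there would move the number in the same way. As far as these compounds go, it is also open whether the bromo would give a similar step on compound 2, which has no methoxy group, since the present step comes from a single pair.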